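The source may hold more compounds than are shown below. What is called first, only, known or untested is meant among the compounds shown, and "the series" means these compounds.

Compounds measured so far:
compound 1 `Cc1cc(O)c(C(=O)/C=C/c2ccccc2Cl)c(-c2ccc(Cl)cc2)c1C(=O)/C=C/c1ccccc1Cl` gives 30000 nM in an ADME assay on HEK293 cells (Homo sapiens) for cytotoxicity, read by MTT assay, with a stated time of 24 h; a lower number here means a stronger inhibitor, a higher number a weaker inhibitor;
compound 2 `Cc1cc(O)c(C(=O)/C=C/c2ccc3ccccc3c2)c(-c2ccc(Cl)cc2)c1C(=O)/C=C/c1ccc2ccccc2c1` is reported as "not active" (no number reported) in this assay.

Compound 2 stands without a single number in this assay: its result is given only as inactive, so no figure can be set beside the value of compound 1. Compound 3 `Cc1cc(O)c(C(=O)/C=C/c2ccc3ccccc3c2)c(-c2ccccc2)c1C(=O)/C=C/c1ccc2ccccc2c1` is the next compound, still to be measured in this assay. It differs from compound 2 by hydrogen in place of chloro on an aromatic carbon, a hydrogen in place of chloro on an aromatic carbon. For the measured compounds named here, no step between two measured compounds covers this change, so its size and direction are unknown from the data. Since compound 2 gave no number, the expectation is that compound 3 will also sit in the weak range of this assay, with a real chance that only a limit is reported. Compound 3 is estimated at 60000 nM, within a range from 25000 nM to 150000 nM.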

Compound 3, half-maximal inhibitory concentration: "not active" (no number reported)
Nothing numeric was reported for compound 3; the estimate stays without a comparison.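

Compound 2 and compound 3 are both reported only as not active in this assay, so no step can be read between them. The compounds shown leave open how 4-chlorophenyl to phenyl shifts cytotoxicity in numbers. No evidence at hand bears on this result.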